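A few compounds are considered here, and "the series" means these few. Any claim that something is new, unique, unknown or untested is made for them only; others in the source may bear on it.

Measured compounds, values from a functional assay on HT cells (Homo sapiens) for antiproliferative activity, read by fluorescence, with a stated time of 72 h; on this read-out higher numbers stand for weaker inhibition of growth and lower numbers for stronger inhibition of growth:

compound 1, `CC(C)c1n[nH]c2c(NCc3ccc(-c4ccccn4)cc3)nc(SC(CO)C(C)C)nc12`, 980 nM
compound 2, `CSc1nc(NCc2ccc(-c3ccccn3)cc2)c2[nH]nc(C(C)C)c2n1`, 783 nM
compound 3, `CC(C)c1n[nH]c2c(NCc3ccc(-c4ccccn4)cc3)nc(S)nc12`, 2760 nM

Compound 1 stands second highest of the three numbers. Its nearest neighbour is compound 2, a 1.3-fold lower number from compound 1 to compound 2 (0.10 log units; within the scatter), a gap that stays within the scatter. The furthest is compound 3, a 2.8-fold higher number from compound 1 to compound 3 (0.45 log units; beyond the scatter), a modest step beyond the scatter. The same reading comes from a 3.5-fold higher number from compound 2 to compound 3 (0.55 log units; beyond the scatter).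

Compound 4, `CC(=O)NCCSc1nc(NCc2ccc(-c3ccccn3)cc2)c2[nH]nc(C(C)C)c2n1`, is not yet measured. Its difference from compound 1: 2-acetamidoethyl in place of 1-(hydroxymethyl)-2-methylpropyl on a sulfur.

Among the compounds with values here, two measured steps bear on this change, both made at the same sulfur. Removing the whole group leaves a bare sulfur and costs potency, as in a 2.8-fold higher number from compound 1 to compound 3 (0.45 log units; beyond the scatter). Cutting the group down to methyl changes nothing beyond the scatter, as in a 1.3-fold lower number from compound 1 to compound 2 (0.10 log units; within the scatter). The substituent on the sulfur therefore seems to matter mainly by being present at all; its size and its hydroxymethyl have not shown a measurable effect between compound 1 and compound 2. Within the data shown here, no measured step shows an acetamide at this place, so the amide part is an open question.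

With a chain of the same heavy-atom count in place, compound 4 is expected to stay close to compound 1, and the estimated step is a 1.0-fold lower number from compound 1 to compound 4 (0.01 log units; within the scatter), within the scatter. The estimate for compound 4 in this assay is 950 nM, with a range of 450 nM to 2000 nM.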

Compound 4, concentration for 50% growth inhibition: 71 nM
Beside the measured number, compound 4's estimate is 13-fold (1.13 log units) above it, and the stated range ends above it.
By their numbers in this assay, from the lowest: compound 4; then compounds 2 and 1 (each within the scatter of the next); then compound 3.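

In this assay, the group on the sulfur proves to matter by its identity and not only by being present: 2-acetamidoethyl in place of 1-(hydroxymethyl)-2-methylpropyl gives a large gain (a 14-fold lower number from compound 1 to compound 4 (1.14 log units; beyond the scatter)), although the two groups have matching counts of heavy atoms, hydrogen-bond donors and hydrogen-bond acceptors and neither contains a ring. Heavy-atom count alone does not sort the series, since compound 1 and compound 2 lie within the scatter of each other while compound 4 separates clearly from the methyl thioether (an 11-fold lower number from compound 2 to compound 4 (1.04 log units; beyond the scatter)). Within the data shown here, the span available at this sulfur is also wider than the earlier compounds suggested, as the comparison with the free thiol shows (a 39-fold lower number from compound 3 to compound 4 (1.59 log units; beyond the scatter)).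

Still open, going by these compounds, is which part of the 2-acetamidoethyl group carries the gain, a question that a free amine or a carboxylic acid at the chain end, or a longer chain bearing the same acetamide, would help to separate. No measurement at hand accounts for the gain seen with compound 4.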